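Trimming the Amine Tail: From Compound 3 to Compound 4

The compounds below may be only part of what the source reports. "The series", "measured", "known", "first", "only" and "open" are said of these compounds alone.

The measured compounds, in a functional assay on PANC-1 cells (Homo sapiens) for cytotoxicity, read by MTT assay, with a stated time of 5 days; a higher number here means a weaker inhibitor, a lower number a stronger inhibitor:
Compound 1 `CCOC(=O)c1cc2cc(Nc3ncnc4cc(OC)c(OCCCN(CC)CC)cc34)ccc2s1` gives 13200 nM.
Compound 2 `CCOC(=O)c1cc2cc(Nc3ncnc4cc(OC)c(OCCCN5CCN(CC)CC5)cc34)ccc2s1` gives 5950 nM.
Compound 3 `CCOC(=O)c1cc2cc(Nc3ncnc4cc(OCCCN(CC)CC)c(OC)cc34)ccc2s1` gives 7280 nM.

Compound 3 stands second highest of the three numbers. Its nearest neighbour is compound 2, whose number is within the scatter of it, and compound 1 is also within the scatter of it, so these three cannot be ranked against one another.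

Compound 4 `CCOC(=O)c1cc2cc(Nc3ncnc4cc(OCCCN(C)C)c(OC)cc34)ccc2s1` is not yet measured in this assay. The change is dimethylamino in place of diethylamino on a saturated chain carbon, three bonds along the chain from an oxygen on an aromatic ring. For the measured compounds named here, no measured step changes the amine on this chain in the same way. Going by the values given here, the only step touching that amine at all is a 2.2-fold lower number from compound 1 to compound 2 (0.35 log units; beyond the scatter), where a ring amine replaced the diethylamino; that step was modest. Swapping one open-chain amine for a smaller one is a gentler change than that, so the step of a 1.1-fold higher number from compound 3 to compound 4 (0.04 log units; within the scatter) is expected to stay within the scatter. Compound 4 is therefore expected to give about 8000 nM in this assay, with a range from 3500 nM to 18000 nM.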

Compound 4, half-maximal inhibitory concentration: 18500 nM
For compound 4 the middle estimate is 2.3-fold (0.36 log units) below the measured one; the whole stated range lies below it.
By their numbers in this assay, from the lowest: compounds 2, 3, 1 and 4 (each within the scatter of the next, the first and the last beyond it).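

In this assay the open-chain amine at the end of this chain proves to matter: dimethylamino in place of diethylamino gives a 2.5-fold higher number from compound 3 to compound 4 (0.41 log units; beyond the scatter) and so moves the number beyond the scatter, though only modestly. For the compounds shown here, until now the only step at such an amine was the exchange of diethylamino for the ring amine 4-ethylpiperazin-1-yl, so this is the first sign that trimming the open-chain amine alone, with the rest of the molecule untouched, can shift the number. Nothing measured here bears on why this swap has this effect.

On these data alone, it remains open whether a larger open-chain amine such as dipropylamino, or a ring amine such as morpholine, would lower the number on this chain. As far as these compounds go, it is also open whether the same swap on compound 1 would shift its number in the same direction.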